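The source may report more compounds than this note shows. Statements on the series, on what has been measured and on what is new or still open speak of the compounds shown alone.

Compound 1 `CCOCc1c(C)coc1-c1ccc2c(c1OC)CCCC2(C)C`: 22.9 uM
Compound 2 `COCc1c(C)coc1-c1ccc2c(c1OC)CCCC2(C)C`: 19.4 uM

In a functional assay on A549 cells (Homo sapiens) for cytotoxicity, read by sulforhodamine B assay, with a stated time of 3 days (on this read-out lower numbers stand for an effect already at smaller amounts and higher numbers for an effect only at larger amounts of compound), compound 1, at 22.9 uM, has only compound 2 for comparison, and the two numbers cannot be told apart: a 1.2-fold lower number from compound 1 to compound 2 (0.07 log units; within the scatter). Compound 3 `COc1c(-c2occ(C)c2CO)ccc2c1CCCC2(C)C` changes the same side chain, ethoxymethyl to hydroxymethyl: hydrogen in place of ethyl on an oxygen on a saturated carbon. Within the data shown here, only one measured step bears on this, a 1.2-fold lower number from compound 1 to compound 2 (0.07 log units; within the scatter), and it replaces an ether chain with a shorter one, so a free hydroxy remains untested. A step beyond the scatter is therefore not expected, in either direction. The expected change is a 1.2-fold lower number from compound 1 to compound 3 (0.08 log units; within the scatter). For compound 3 the estimated value is 19 uM, with an expected range of 8 uM to 42 uM.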

Compound 3, concentration for half-maximal effect: 23.3 uM
Beside the measured number, compound 3's estimate is 1.2-fold (0.09 log units) below it, and the stated range covers the measured number.
By their numbers in this assay, from the lowest: compounds 2, 1 and 3 (each within the scatter of the next).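

With hydrogen in place of ethyl on this oxygen, the result is a 1.0-fold higher number from compound 1 to compound 3 (0.01 log units; within the scatter) in this assay, and hydrogen in place of methyl gives a 1.2-fold higher number from compound 2 to compound 3 (0.08 log units; within the scatter) as well. The free hydroxy of hydroxymethyl thus reads like both ethers, so at this position neither ether chain nor its absence produces a step beyond the scatter. No evidence is at hand that would account for this flat result. Open, from the compounds shown here alone, is whether an amine, a carboxylic acid or a longer chain such as butoxymethyl in place of hydroxymethyl would move the number beyond the scatter.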